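A few compounds are considered here, and "the series" means these few. Any claim that something is new, unique, unknown or untested is made for them only; others in the source may bear on it.

Measured compounds, in a functional assay on PC-3 cells (Homo sapiens) for antiproliferative activity, read by MTT assay, with a stated time of 72 h; a lower number here means a stronger inhibitor, a higher number a weaker inhibitor:
compound 1, `CC/C=C/C(=O)Nc1cc2c(N3CCc4ccccc43)ncnc2cc1OC`: 5890 nM
compound 2, `COc1cc2ncnc(N3CCc4ccccc43)c2cc1NC(=O)/C=C/C(C)C`: 6530 nM
compound 3, `CCC/C=C/C(=O)Nc1cc2c(N3CCc4ccccc43)ncnc2cc1OC`: 4240 nM

Compound 3 gives the lowest of the three numbers, but the separation is small: a 1.4-fold lower number from compound 1 to compound 3 (0.14 log units; within the scatter) and a 1.5-fold lower number from compound 2 to compound 3 (0.19 log units; within the scatter) both sit within the scatter, as does a 1.1-fold higher number from compound 1 to compound 2 (0.04 log units; within the scatter). Across these three, moving a methyl along the alkenyl chain of the amide, or swapping propyl for isopropyl on its double-bonded carbon, produces nothing that can be read as a real difference. On the numbers shown, compound 3 is therefore not separable from compound 1 or compound 2.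

Compound 4, `COc1cc2ncnc(N3CCc4ccccc43)c2cc1NC(=O)/C=C/CN1CCN(C)CC1`, is not yet measured. Relative to compound 3 the change is 4-methylpiperazin-1-yl in place of ethyl on a saturated chain carbon bound to a double-bonded chain carbon. Within the data shown here, none of the measured steps tests a change of this kind; the only one placed on the same kind of chain carbon is a 1.1-fold higher number from compound 1 to compound 2 (0.04 log units; within the scatter), and it was flat, as were the other two. The amide tail has so far tolerated small edits without consequence, but the incoming group is larger and of a different character than anything measured, so its direction cannot be read from the series. Compound 4 is accordingly estimated at 3200 nM, within 800 nM to 13000 nM. Among the measured compounds shown here, the step of a 1.3-fold lower number from compound 3 to compound 4 (0.12 log units; within the scatter) is expected to stay within the scatter, with the wide range reflecting that no measured step bears directly on this change.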

Compound 4, half-maximal inhibitory concentration: 9180 nM
The estimate for compound 4 lay 2.9-fold (0.46 log units) below the measured number; measured number inside the range.
By their numbers in this assay, from the lowest: compounds 3, 1, 2 and 4 (each within the scatter of the next, the first and the last beyond it).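

In this assay, among these compounds, replacing ethyl with 4-methylpiperazin-1-yl on the saturated chain carbon bound to a double-bonded chain carbon gives a 2.2-fold higher number from compound 3 to compound 4 (0.34 log units; beyond the scatter) and is the only step to pass the scatter, so this position does not tolerate every edit without consequence. The separation is modest and holds only against compound 3, since a 1.4-fold higher number from compound 2 to compound 4 (0.15 log units; within the scatter) and a 1.6-fold higher number from compound 1 to compound 4 (0.19 log units; within the scatter) both stay within the scatter and a consistent separation of compound 4 from the small alkenyl amides cannot be claimed. No measurement shown offers a reason for the step.

On these data alone, whether the ring or the amine drives the step remains open, as a dimethylamino group or morpholin-4-yl on the same saturated chain carbon could show whether other groups also separate from compound 3. Among the compounds shown here, also open is whether the step would persist with a longer alkyl chain in the comparison or on a core other than the one shared by these compounds.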